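Swapping One Ring Substituent on Compound 1

A few compounds are considered here, and "the series" means these few. Any claim that something is new, unique, unknown or untested is made for them only; others in the source may bear on it.

- compound 1 `O=C1CC(Oc2ncc(F)cn2)CN1c1cnn2c1CN(C(=O)Nc1cc(F)c(F)c(F)c1)C(C1CC1)C2` gives 96200 nM
- compound 2 `CC1CN(C(=O)Nc2cc(F)c(F)c(F)c2)Cc2c(N3CC(C#N)CC3=O)cnn21` gives 115000 nM

Both numbers come from a toxicity assay on HepG2 2.2.15 cells (Homo sapiens) for cytotoxicity, read by CellTiter-Glo (a higher number here means that more compound is tolerated, a lower number that less compound is tolerated), and lie within the usual scatter of each other, so compound 1 stands together with compound 2 on the data so far. Going by the values given here, compound 3 `Cc1cnc(C2CC(=O)N(c3cnn4c3CN(C(=O)Nc3cc(F)c(F)c(F)c3)C(C3CC3)C4)C2)s1` keeps the core of compound 1 but carries 5-methyl-1,3-thiazol-2-yl in place of (5-fluoropyrimidin-2-yl)oxy on a saturated ring carbon as its only change. Among the compounds with values here, no measured pair shows this swap alone, so the forecast is uncertain. In this assay no shift beyond the scatter is expected, and the expected step is a 1.2-fold lower number from compound 1 to compound 3 (0.08 log units; within the scatter) as a best guess. For compound 3 the estimated value is 80000 nM with an expected range from 35000 nM to 130000 nM for a single measurement.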

Compound 3, half-maximal cytotoxic concentration: 96200 nM
Estimate against measurement, compound 3: 1.2-fold (0.08 log units) below, and the stated range covers the measured number.
By their numbers in this assay, from the lowest: compounds 1, 3 and 2 (each within the scatter of the next).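

In this assay, putting 5-methyl-1,3-thiazol-2-yl in place of (5-fluoropyrimidin-2-yl)oxy on this saturated ring carbon gives no change at the digits printed from compound 1 to compound 3 (within the scatter) on the shared core. On this carbon, then, a five-membered aromatic ring with sulfur and a six-membered aromatic ring attached through oxygen read alike for cell tolerance. Nothing measured here explains this match. Whether an amine or a carboxylic acid on the same carbon would read alike stays open, and both compounds carry aromatic rings there, so a non-aromatic group remains untested among the compounds shown.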